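The compounds below may be only part of what the source reports. "The series", "measured", "known", "first", "only" and "open" are said of these compounds alone.

Measured compounds:
compound 1, `COc1ccc(S(=O)(=O)N2CCc3cccc(-c4ccc(N)cc4)c32)cc1`, 288 nM
compound 2, `COc1ccc(S(=O)(=O)N2CCc3cccc(-c4ccc(F)nc4)c32)cc1`, 135 nM
compound 3, `COc1ccc(S(=O)(=O)N2CCc3cccc(-c4ccco4)c32)cc1`, 94.5 nM

The three compounds share one core and differ only in the aromatic group attached to it. In a functional assay on NCI-H460 cells (Homo sapiens) for inhibition, with a stated time of 72 h (on this read-out lower numbers stand for stronger inhibition and higher numbers for weaker inhibition), compound 3 gives the lowest of the three numbers. Its distance to compound 2 is small, a 1.4-fold lower number from compound 2 to compound 3 (0.15 log units; within the scatter), so these two cannot be ordered. Its distance to compound 1 is larger, a 3.0-fold lower number from compound 1 to compound 3 (0.48 log units; beyond the scatter), and compound 2 also stands apart from compound 1, a 2.1-fold lower number from compound 1 to compound 2 (0.33 log units; beyond the scatter).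

Compound 4, `COc1ccc(S(=O)(=O)N2CCc3cccc(-c4ccc(F)c(F)c4)c32)cc1`, has not been measured. It differs from compound 3 in one place: 3,4-difluorophenyl in place of furan-2-yl on an aromatic carbon. Among the compounds with values here, two measured steps bear on this change. The step from compound 2 to compound 3 shows that exchanging a six-membered aromatic ring carrying fluorine for furan-2-yl left the number within the scatter. The step from compound 1 to compound 3 shows that a six-membered ring carrying an amino group gave a modestly higher number than furan-2-yl. Since compound 4 carries fluorine and no amino group, compound 2 is the closer guide, and the expected step of a 1.4-fold higher number from compound 3 to compound 4 (0.14 log units; within the scatter) is small. Compound 4 is therefore estimated at 130 nM in this assay, with a range from 60 nM to 300 nM.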

Compound 4, half-maximal inhibitory concentration: 46 nM
Estimate against measurement, compound 4: 2.8-fold (0.45 log units) above; the measured number lies below the stated range.
By their numbers in this assay, from the lowest: compound 4; then compounds 3 and 2 (each within the scatter of the next); then compound 1.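

In this assay, within the data shown here, the earlier compounds had left furan-2-yl level with the fluorinated six-membered ring and ahead of the amino-bearing one at this aromatic carbon, but a six-membered aromatic ring of carbon only now goes beyond it, with a 2.1-fold lower number from compound 3 to compound 4 (0.31 log units; beyond the scatter). A six-membered ring at this place therefore does not by itself set the number: compound 1 and compound 2 also carry one, yet 3,4-difluorophenyl stands apart from both, with a 2.9-fold lower number from compound 2 to compound 4 (0.47 log units; beyond the scatter) and a 6.3-fold lower number from compound 1 to compound 4 (0.80 log units; beyond the scatter). Nothing available accounts for these differences, so the result stands as an observation about these four compounds alone.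

The step between the pyridine and 3,4-difluorophenyl changes both the ring atoms and the number of fluorines at once, so the compounds shown cannot separate these two changes from each other. As far as these compounds go, it also remains open how an unsubstituted phenyl ring, a phenyl ring with a single fluorine, or one carrying chlorine or a nitrile would compare with 3,4-difluorophenyl on this aromatic carbon.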